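The compounds below may be only part of what the source reports. "The series", "measured", "known", "first", "only" and "open" are said of these compounds alone.

Working notes on the series. Three compounds sharing one core have been run in a functional assay on UACC-62 cells (Homo sapiens) for inhibition, read by sulforhodamine B assay, with a stated time of 48 h; a lower number here means a stronger inhibitor of growth, a higher number a weaker inhibitor of growth. Compound 1 `COc1cc(-c2nn(-c3cccc(NC(=O)c4cccc(C(F)(F)F)c4)c3)cc2-c2ccncc2)ccc1Cl` gives 1940 nM in this assay. Compound 2 `COc1cc(-c2nn(-c3cccc(NC(=O)Nc4ccc(Cl)c(Cl)c4)c3)cc2-c2ccncc2)ccc1Cl` gives 773 nM. Compound 3 `COc1cc(-c2nn(-c3cccc(NC(=O)c4ccc(Cl)c(C(F)(F)F)c4)c3)cc2-c2ccncc2)ccc1Cl` gives 2100 nM, the highest of the three numbers; the gap to compound 1 is within the scatter, while the gap to compound 2 is beyond it, as a 2.7-fold higher number from compound 2 to compound 3 (0.43 log units; beyond the scatter) shows. Across the three, the only step beyond the scatter is the one that puts an amino-linked aryl group on the carbonyl carbon, a 2.5-fold lower number from compound 1 to compound 2 (0.40 log units; beyond the scatter), with a 1.1-fold higher number from compound 1 to compound 3 (0.03 log units; within the scatter) showing that the extra chloro alone does not move the number.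

Compound 4 `COc1cc(-c2nn(-c3cccc(NC(=O)Nc4ccc(Cl)c(C(F)(F)F)c4)c3)cc2-c2ccncc2)ccc1Cl` has not yet been measured in this assay. It differs from compound 3 in one place: (4-chloro-3-(trifluoromethyl)phenyl)amino in place of 4-chloro-3-(trifluoromethyl)phenyl on a carbonyl carbon. For the measured compounds named here, this is the same kind of change as the one from compound 1 to compound 2, and the reverse of the one from compound 2 to compound 3, so both of those steps bear on it and both were modest and beyond the scatter. A lower number for compound 4 is therefore expected, of about the size seen in a 2.5-fold lower number from compound 1 to compound 2 (0.40 log units; beyond the scatter), meaning an estimated step of a 2.6-fold lower number from compound 3 to compound 4 (0.42 log units; beyond the scatter). The estimate for compound 4 in this assay is 800 nM, with a range from 350 nM to 1900 nM.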

Compound 4, concentration for 50% growth inhibition: 737 nM
The estimate for compound 4 lay 1.1-fold (0.04 log units) above the measured number; low and high end bracket the measured number.
By their numbers in this assay, from the lowest: compounds 4 and 2 (each within the scatter of the next); then compounds 1 and 3 (each within the scatter of the next).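

With the aryl ring carrying both chloro and trifluoromethyl, the amino link on the carbonyl carbon again lowers the number in this assay, a 2.8-fold lower number from compound 3 to compound 4 (0.45 log units; beyond the scatter), a step close in size to a 2.5-fold lower number from compound 1 to compound 2 (0.40 log units; beyond the scatter), so the effect of this change now holds in two matched pairs and across two aryl patterns, and the same direction appears in a 2.6-fold lower number from compound 1 to compound 4 (0.42 log units; beyond the scatter), where the chloro is added as well. Once the amino link is present, trifluoromethyl in place of chloro on the aryl ring leaves the number unmoved, a 1.0-fold lower number from compound 2 to compound 4 (0.02 log units; within the scatter), so among these four compounds the link separates the numbers, while neither aryl change does. Nothing given here accounts for the lower number seen with the amino link.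

The compounds shown leave open whether the nitrogen itself or the hydrogen on it goes with the lower number, which a methylamino group or an oxygen link on the carbonyl carbon would help to separate. They also leave open how far the aryl ring tolerates other groups, such as a nitrile or a carboxylic acid, in place of the trifluoromethyl.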